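Aminopyrimidine series: piperazine to thiazolylsulfanyl exchange

This account rests on a few compounds, and the source may have more. Where it says the series, first, only, none or still open, it means among the compounds named here.

Measured so far:
compound 1 `FC(F)(F)c1ccc(CSc2nc(N3CCNCC3)cc(C(F)(F)F)n2)cc1`: 10700 nM
compound 2 `FC(F)(F)c1ccc(CSc2nc(N3CCN(c4ccccn4)CC3)cc(C(F)(F)F)n2)cc1`: > 50000 nM

Among the compounds with values here, compound 1 `FC(F)(F)c1ccc(CSc2nc(N3CCNCC3)cc(C(F)(F)F)n2)cc1` is the only compound of the series with a numerical result; in a functional assay on MCF7 cells (Homo sapiens) for inhibition, read by MTT assay, with a stated time of 72 h (on this read-out lower numbers stand for stronger inhibition and higher numbers for weaker inhibition), compound 1 gives 10700 nM. Compound 2 `FC(F)(F)c1ccc(CSc2nc(N3CCN(c4ccccn4)CC3)cc(C(F)(F)F)n2)cc1` returns only a limit in this assay, > 50000 nM. Within the data shown here, the single step that can be sized, an at least 4.6-fold higher number from compound 1 to compound 2 (0.66 log units; beyond the scatter), is beyond the scatter and rests on (the limit of > 50000 nM in this assay, at which 1 of the 2 values shown sits).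

Compound 3 `Cc1csc(Sc2cc(C(F)(F)F)nc(SCc3ccc(C(F)(F)F)cc3)n2)n1` differs from compound 1 in one place: (4-methyl-1,3-thiazol-2-yl)sulfanyl in place of piperazin-1-yl on an aromatic carbon. Among the measured compounds shown here, no measured pair shows exactly this exchange. For the measured compounds named here, the one step available weakens inhibition when the amine nitrogen in the ring of compound 1 is substituted, and compound 3 gives up that ring altogether, so a further weakening seems the more likely direction, without a firm basis for its size.

Compound 3 is therefore expected to sit at 25000 nM, between 8000 nM and 80000 nM; the step of a 2.3-fold higher number from compound 1 to compound 3 (0.37 log units; beyond the scatter) is expected to be modest and a limit rather than a number is a real possibility.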

Compound 3, half-maximal inhibitory concentration: 14500 nM
Compound 3: middle estimate off by 1.7-fold (0.24 log units), on the high side, and the stated range covers the measured number.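

In this assay, (4-methyl-1,3-thiazol-2-yl)sulfanyl in place of piperazin-1-yl on this aromatic carbon gives a 1.4-fold higher number from compound 1 to compound 3 (0.13 log units; within the scatter), so compound 1 and compound 3 cannot be told apart on this read-out. This position therefore accepts a complete exchange of the piperazin-1-yl group, including loss of its ring amine nitrogen, without a change that can be read in this assay. The weakening seen earlier when pyridin-2-yl was placed on that nitrogen thus does not extend to this replacement of the whole piperazine, although both values remain weak on this read-out and neither pair says what would strengthen inhibition.

No pair shown separates the contribution of the thiazole ring from that of its sulfur link, and the effect of a morpholine, a simple dialkylamine or a carboxylic acid on this same carbon remains open. The size of the pyridin-2-yl step also remains open, as compound 2 is known only as a limit: the limit of > 50000 nM in this assay, at which 1 of the 3 values shown sits.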